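The source may report more compounds than this note shows. Statements on the series, on what has been measured and on what is new or still open speak of the compounds shown alone.

Series notes. Compound 1 `COc1ccc(Cc2nnc3n2N=C(c2ccc(Cl)cc2)CS3)cc1` and compound 2 `COc1ccc(Cc2nnc3n2N=C(c2ccc(F)cc2)CS3)cc1` share one core; compound 3 `COc1ccc(CCc2nnc3n2N=C(c2ccc(Cl)cc2)CS3)cc1` and compound 4 `COc1ccc(CCc2nnc3n2N=C(c2ccc(F)cc2)CS3)cc1` share another. The difference between the two cores is not broken down here. In a functional assay on the whole organism (strain BALB/c) with Mus musculus as the target, in the writhing test, with a stated time of 1 h, at a dose of 200 mg/kg by the oral route (a higher number here means a stronger effect of the compound at the dose given, a lower number a weaker effect), compound 1 gives 39%, and compound 2 gives 31.5%. The change between these two, (fluoro in place of chloro on an aromatic carbon), made a step of a number 7.5 percentage points lower from compound 1 to compound 2 (within the scatter). Compound 3 gives 62.4% in this assay, the highest of the three measured numbers, with its gaps to compound 1 and to compound 2 both beyond the scatter. The same change is made again from compound 3 to compound 4: fluoro in place of chloro on an aromatic carbon. Among the compounds shown it occurs twice. Going by the values given here, its single measured instance moved the read-out only within the scatter, so the step from compound 3 to compound 4 is expected to be similar, estimated as a number 7.4 percentage points lower from compound 3 to compound 4 (within the scatter), resting on the measured a number 7.5 percentage points lower from compound 1 to compound 2 (within the scatter). Compound 4 is therefore expected to give about 55% in this assay, most likely between 42% and 66%.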

Compound 4, a percentage reported as inhibition, in the whole organism at one dose (the size of the read-out at that dose, not a potency): 37%
Compound 4: middle estimate off by 18 percentage points, on the high side; measured number outside the range, below it.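

Carrying fluoro in place of chloro on an aromatic carbon to the core of compound 3 in this assay gave a step of a number 25.4 percentage points lower from compound 3 to compound 4 (beyond the scatter). Set beside the earlier step, the size of this change does not carry over unchanged between the two cores: the same change on two cores in this assay, a number 7.5 percentage points lower (within the scatter) from compound 1 to compound 2 and a number 25.4 percentage points lower (beyond the scatter) from compound 3 to compound 4, 17.9 percentage points apart, beyond the scatter of two such steps

A step read on one core is therefore a poor guide to the same change on the other core in this series, but with one pair on each core this does not show which feature of the cores sets the difference, nor how the change would behave on a third core.

The compounds shown hold only chloro and fluoro at this place, so it remains open how a bromo, a nitrile or an amine there would read out on either core. Also open, going by these compounds, is whether a longer chain in the core of compound 3 would keep the same sensitivity to this change.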